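The source may report more compounds than this note shows. Statements on the series, on what has been measured and on what is new or still open speak of the compounds shown alone.

Working notes on the series. Compound 1 `Nc1sc(-c2ccc(Cl)cc2)c(-c2ccc(Cl)cc2)c1C(=O)NC1CC1` is the one open-chain amide here, and in a functional assay on PC-3 cells (Homo sapiens) for cytotoxicity, read by sulforhodamine B assay, with a stated time of 72 h (on this read-out lower numbers stand for stronger inhibition and higher numbers for weaker inhibition), compound 1 gives 3680 nM. Compound 2 `O=C1CC(c2ccccc2)c2c(sc(-c3ccc(Cl)cc3)c2-c2ccc(Cl)cc2)N1` carries a phenyl on a saturated ring carbon of its fused system. In this assay compound 2 reaches only the limit of the assay, > 50000 nM, and no number. Compound 3 `O=C1CC(c2cccs2)c2c(sc(-c3ccc(Cl)cc3)c2-c2ccc(Cl)cc2)N1` differs from compound 2 by thiophen-2-yl in place of phenyl on that saturated ring carbon. In this assay compound 3 likewise reaches only the limit, > 50000 nM, not a number. Within the data shown here, the single step between measured compounds differing in one place, a step that the two limits leave unreadable from compound 2 to compound 3, is thus not readable, and the two limits say nothing about whether the two groups differ. Compound 3 stands at a limit rather than at a value, and the limit of > 50000 nM in this assay, at which 2 of the 3 values shown sit, marks where most of the series sits.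

Compound 4 `O=C1CC(c2ccco2)c2c(sc(-c3ccc(Cl)cc3)c2-c2ccc(Cl)cc2)N1` carries the change (furan-2-yl in place of thiophen-2-yl on a saturated ring carbon). Among the measured compounds shown here, the only measured step that bears on it, a step that the two limits leave unreadable from compound 2 to compound 3, has no readable size, so the measured compounds give neither a direction nor a size; the nearest comparison left both compounds at the limit. Compound 4 is therefore expected to sit at the limit as well, with an estimate of 60000 nM in this assay, ranging from 20000 nM to 200000 nM. The step this estimate means, a step that the limit leaves unreadable from compound 3 to compound 4, is expected to be none beyond the scatter.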

Compound 4, half-maximal inhibitory concentration: > 50000 nM
Compound 4 gave a limit, no number; the forecaster's own chance of this, stated with the estimate: 80%; the middle value lies beyond the limit too.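

In this assay, among these compounds, compound 4 gives > 50000 nM, a limit and not a number, so no step among compound 2, compound 3 and compound 4 can be read. The three share one limit: the limit of > 50000 nM in this assay, at which 3 of the 4 values shown sit.

The compounds shown leave open whether phenyl, thiophen-2-yl and furan-2-yl on the saturated ring carbon differ at all in this read-out.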